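An Ester-Bearing Side Chain in Place of Azido

The compounds below may be only part of what the source reports. "The series", "measured", "known", "first", "only" and "open" are said of these compounds alone.

Three analogues of one shared core were tested in a functional assay on MCF7 cells (Homo sapiens) for cytotoxicity, read by neutral red uptake, with a stated time of 3 days; a higher number here means a weaker inhibitor, a lower number a stronger inhibitor. Compound 1 `Cc1c(F)c(N)c2c(=O)cc(-c3ccc(N)c(F)c3)oc2c1F` carries methyl on the aromatic carbon in question and gives 13 nM in this assay. Compound 2 `CCCCCCc1c(F)c(N)c2c(=O)cc(-c3ccc(N)c(F)c3)oc2c1F` bears hexyl there; in this assay compound 2 reaches only the limit > 10000 nM. Compound 3 `[N-]=[N+]=Nc1c(F)c(N)c2c(=O)cc(-c3ccc(N)c(F)c3)oc2c1F` has azido at the same carbon and gives 460 nM in this assay, the highest of the two numbers reported, with compound 1 nearest at a 35-fold higher number from compound 1 to compound 3 (1.55 log units; beyond the scatter).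

The step from compound 3 to compound 4 `CN(C)CCCC(=O)OCc1c(F)c(N)c2c(=O)cc(-c3ccc(N)c(F)c3)oc2c1F` changes the substituent on this carbon: (((3-(dimethylamino)propyl)carbonyl)oxy)methyl in place of azido on an aromatic carbon. For the measured compounds named here, two measured steps bear on it. Lengthening the chain gave an at least 760-fold higher number from compound 1 to compound 2 (2.88 log units; beyond the scatter), and the shorter azido then gave an at least 21-fold lower number from compound 2 to compound 3 (1.33 log units; beyond the scatter). A substantially larger group at this carbon thus goes with a higher number, and compound 4 brings in the largest group of the set. Compound 4 is therefore expected to give a higher number than compound 3, with an estimated step of a 4.3-fold higher number from compound 3 to compound 4 (0.64 log units; beyond the scatter). The estimate for compound 4 in this assay is 2000 nM, expected to fall between 300 nM and 15000 nM.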

Compound 4, half-maximal inhibitory concentration: 29 nM
Compound 4: the middle estimate sits 69-fold (1.84 log units) above what was measured, and the stated range ends above it.
By their numbers in this assay, from the lowest: compound 1; then compound 4; then compound 3. At a limit, above all of these: compound 2.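

In this assay the size of the group does not by itself set the number at this aromatic carbon: the (((3-(dimethylamino)propyl)carbonyl)oxy)methyl group, the largest in the set, gives a 16-fold lower number from compound 3 to compound 4 (1.20 log units; beyond the scatter) and so breaks the link between a larger group and a higher number that compound 1, compound 2 and compound 3 had suggested. Methyl still holds the lowest number, yet the gap to this much larger group is only a 2.2-fold higher number from compound 1 to compound 4 (0.35 log units; beyond the scatter) and is the smallest of the new steps. The long chain of the hexyl analogue reads differently, with an at least 340-fold lower number from compound 2 to compound 4 (2.53 log units; beyond the scatter) as a step that rests on a limit and not on a number, so chain length alone does not decide the outcome here: the limit of > 10000 nM in this assay, at which 1 of the 4 values shown sits.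

Which part of the new chain goes with the lower number, the dimethylamino group or the ester, stays open among the compounds shown. Equally open, on these data alone, is where a hydroxymethyl group, an amide in place of the ester, or a chain ending in a carboxylic acid would fall on this carbon.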